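The compounds below may be only part of what the source reports. "The series", "measured", "known", "first", "only" and "open" are said of these compounds alone.

Working notes on the series. The parent compound 1 `COc1cc[nH]c1/C=C1\C(=O)Nc2ccc([N+](=O)[O-])cc21` carries a hydrogen at the position of interest and in a functional assay on MDA-MB-435 cells (Homo sapiens) for antiproliferative activity, read by MTT assay, with a stated time of 5 days (on this read-out higher numbers stand for weaker inhibition and lower numbers for stronger inhibition), compound 1 gives 7460 nM. Compound 2 `COc1cc[nH]c1/C=C1\C(=O)Nc2ccc([N+](=O)[O-])c(N3CC[C@@H](O)C3)c21` adds 3-hydroxypyrrolidin-1-yl there; in this assay compound 2 gives 88 nM, and an 85-fold lower number from compound 1 to compound 2 (1.93 log units; beyond the scatter). Compound 3 `COc1cc[nH]c1/C=C1\C(=O)Nc2ccc([N+](=O)[O-])c(N[C@H]3CC[C@H](N)C3)c21` carries (3-aminocyclopentyl)amino instead and gives 61 nM; a 120-fold lower number from compound 1 to compound 3 (2.09 log units; beyond the scatter), while a 1.4-fold lower number from compound 2 to compound 3 (0.16 log units; within the scatter). Compound 2 thus sits far from compound 1 and close to compound 3.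

Compound 4 `COc1cc[nH]c1/C=C1\C(=O)Nc2ccc([N+](=O)[O-])c(N3CC[C@@H](N)C3)c21` differs from compound 2 by amino in place of hydroxy on a saturated ring carbon. The step that bears most directly on this is from compound 2 to compound 3, where a larger rearrangement of the same region moved the number only within the scatter; the two large steps from compound 1 show that occupying this position at all, with either group, is what produces the drop. No step beyond the scatter is therefore expected for the exchange of hydroxy for amino. For compound 4 the number in this assay is estimated at 70 nM, within 30 nM to 200 nM, which means an expected step of a 1.3-fold lower number from compound 2 to compound 4 (0.10 log units; within the scatter).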

Compound 4, half-maximal inhibitory concentration: < 10 nM
Compound 4 was reported as a limit; the forecaster's own chance of this, stated with the estimate: 2%; middle value at least 7.0-fold (0.84 log units) away from the limit.
By their numbers in this assay, from the lowest: compounds 3 and 2 (each within the scatter of the next); then compound 1. At a limit, below all of these: compound 4.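

In this assay the identity of the group at this position now matters, not only its presence: amino in place of hydroxy on a saturated ring carbon is a step beyond the scatter (an at least 8.8-fold lower number from compound 2 to compound 4 (0.94 log units; beyond the scatter)), although compound 2 and compound 3 had stood within the scatter of each other. An amino group alone does not account for this, since compound 3 also carries one and still separates from the 3-aminopyrrolidin-1-yl compound (an at least 6.1-fold lower number from compound 3 to compound 4 (0.78 log units; beyond the scatter)). Against the parent, 3-aminopyrrolidin-1-yl gives a large step (an at least 740-fold lower number from compound 1 to compound 4 (2.87 log units; beyond the scatter)).

As far as these compounds go, whether a dimethylamino or hydroxymethyl group on the same ring carbon, or the opposite stereochemistry there, would hold this result remains open. Also open is the true size of these steps, as the value of compound 4 is a limit and not a number: the limit of < 10 nM in this assay, at which 1 of the 4 values shown sits.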